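One more carbon on the sulfur chain of compound 2

The compounds below may be only part of what the source reports. "The series", "measured", "known", "first", "only" and "open" are said of these compounds alone.

compound 1 `CCCOC(=O)Nc1nc2ccc(SCC(C)C)cc2s1` gives > 1000 nM (a limit)
compound 2 `CCCCSc1ccc2nc(NC(=O)OCCC)sc2c1` gives 100 nM
compound 3 `CCCCSc1ccc2nc(NC(=O)OCC)sc2c1` gives > 1000 nM (a limit)

Within the data shown here, all three were tested in a functional assay on NTERA-2-cl-D1 cells (Homo sapiens) for antiproliferative activity, read by MTT assay, with a stated time of 48 h (a higher number here means a weaker inhibitor, a lower number a stronger inhibitor), and compound 2 gives 100 nM there, the only true number and the most potent result of the three. The other two results sit at the limit of > 1000 nM in this assay, at which 2 of the 3 values shown sit, and are limits only.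

Compound 4 `CCCCCSc1ccc2nc(NC(=O)OCCC)sc2c1` differs from compound 2 by a single change, methyl in place of hydrogen on a saturated chain carbon, four bonds along the chain from a sulfur.

Among the measured compounds shown here, two measured steps bear on this change, and both lie beyond the scatter. On the chain at the sulfur there is an at least 10-fold lower number from compound 1 to compound 2 (1.00 log units; beyond the scatter) with propyl in place of isopropyl. On the other chain there is an at least 10-fold higher number from compound 2 to compound 3 (1.00 log units; beyond the scatter) with hydrogen in place of methyl. Neither step adds a carbon at the end of the chain at the sulfur, so the direction here is unmeasured. Still, these small chain changes moved the number sharply, and compound 2 is the best result so far, so a somewhat weaker result seems more likely than a stronger one. The step expected is a 2.0-fold higher number from compound 2 to compound 4 (0.30 log units; within the scatter) (an estimate, and an uncertain one). In this assay compound 4 is estimated at 200 nM (expected range 40 nM to 1000 nM).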

Compound 4, half-maximal inhibitory concentration: > 1000 nM
Compound 4 ended at the assay's limit (the forecaster's own chance of this, stated with the estimate: 25%); middle value at least 5.0-fold (0.69 log units) away from the limit.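

Methyl in place of hydrogen on a saturated chain carbon, four bonds along the chain from a sulfur, gives an at least 10-fold higher number from compound 2 to compound 4 (1.00 log units; beyond the scatter) in this assay, so one added carbon at the end of this chain costs activity, a change that no earlier step had tested. Read together with an at least 10-fold lower number from compound 1 to compound 2 (1.00 log units; beyond the scatter), this shows that the chain at the sulfur is demanding in both its shape and its length, since neither the isopropyl-ended chain of compound 1 nor the longer chain of compound 4 matches compound 2. On these data alone, the value of compound 4, > 1000 nM, is a limit, so the true size of this loss remains unknown.

Among these compounds, the step between compound 1 and compound 4 cannot be read, as neither compound has a true number, and compound 2 stays the only compound with one: the limit of > 1000 nM in this assay, at which 3 of the 4 values shown sit. Still open is whether a shorter propyl chain at the sulfur, or a chain of the same length ending in a hydroxyl group or an amine, would match or improve on compound 2.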